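The compounds below may be only part of what the source reports. "The series", "measured", "known", "first", "only" and "open" are said of these compounds alone.

Measured compounds:
Compound 1 `COc1ccc(C2CC(c3c(O)ccc4ccccc34)=NN2c2ccc(Cl)cc2)c(OC)c1` gives 5400 nM
Compound 2 `COc1cc(OC)c(C2CC(c3c(O)ccc4ccccc34)=NN2c2ccc(Cl)cc2)cc1OC` gives 7800 nM
Compound 3 `COc1cccc(C2CC(c3ccc4ccccc4c3O)=NN2)c1` gives 20800 nM

These three compounds were tested in a functional assay on HCT-116 cells (Homo sapiens) for cytotoxicity, read by crystal violet staining and colony formation, with a stated time of 7 days; on this read-out higher numbers stand for weaker inhibition and lower numbers for stronger inhibition. Compound 1 and compound 2 share one core and differ in a single place: methoxy in place of hydrogen on an aromatic carbon. That change made a 1.4-fold higher number from compound 1 to compound 2 (0.16 log units; within the scatter), so the two values do not separate from each other.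

Compound 3 is built on a different core; how the core of compound 3 differs from the core of compound 1 is not broken down here. Its value is the highest of the three and stands beyond the scatter from both compound 1 and compound 2.

Compound 4 `COc1cc(OC)cc(C2CC(c3ccc4ccccc4c3O)=NN2)c1` has not yet been measured in this assay. It differs from compound 3 in one place: methoxy in place of hydrogen on an aromatic carbon. Going by the values given here, this is the same kind of change as the one from compound 1 to compound 2, though the surroundings are not identical: in compound 2 the new methoxy sits ortho to a methoxy group and para to a methoxy group, while in compound 4 it sits meta to a methoxy group.

On a single precedent, the change from compound 3 to compound 4 is expected to make a 1.3-fold higher number from compound 3 to compound 4 (0.10 log units; within the scatter), resting on the small step seen with a 1.4-fold higher number from compound 1 to compound 2 (0.16 log units; within the scatter) and on the starting value of compound 3 at 20800 nM. Compound 4 is therefore estimated at 26000 nM, with a likely range from 12000 nM to 55000 nM.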

Compound 4, half-maximal inhibitory concentration: 4700 nM
For compound 4 the middle estimate is 5.5-fold (0.74 log units) above the measured one; measured number outside the range, below it.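

In this assay, a methoxy in place of hydrogen on an aromatic carbon gave a 4.4-fold lower number from compound 3 to compound 4 (0.65 log units; beyond the scatter), so on the core of compound 3 this change went with stronger inhibition. The result did not carry over from one core to the other, as the earlier step on the core of compound 1 shows no such gain: the same change on two cores in this assay, a 1.4-fold higher number (0.16 log units; within the scatter) from compound 1 to compound 2 and a 4.4-fold lower number (0.65 log units; beyond the scatter) from compound 3 to compound 4, 6.4-fold (0.81 log units) apart, beyond the scatter of two such steps

Going by these compounds alone, this shows that a step measured on one core cannot simply be transferred to another, but it does not show why the two steps differ or give a general rule, as each core offers only one pair, and the new methoxy also has different surroundings in the two pairs, so the core alone cannot be singled out as what matters.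

On these data alone, it remains open whether another group on the same aromatic carbon of compound 3, such as an ethoxy, a fluorine or an amine, would match the effect of the methoxy. Also open, as far as these compounds go, is whether a methoxy on other aromatic carbons of that core would give a step of similar size.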